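Swapping the chain-end group on a propyl-bearing xanthine-like scaffold

The source may hold more compounds than are shown below. What is called first, only, known or untested is meant among the compounds shown, and "the series" means these compounds.

Measured so far:
Compound 1 `CCCn1c(=O)c2nc(-c3ccc(OCC(=O)NCCN=C(S)Nc4ccc(C)cc4)cc3)[nH]c2n(CCC)c1=O`: 16 nM
Compound 2 `CCCn1c(=O)c2nc(-c3ccc(OCC(=O)NCCN=C(S)Nc4ccc([N+](=O)[O-])cc4)cc3)[nH]c2n(CCC)c1=O`: 15.9 nM

Both compounds were tested in an assay on brain for binding affinity to adenosine receptor A1 (Rattus norvegicus), read by radioligand binding; on this read-out lower numbers stand for stronger inhibition and higher numbers for weaker inhibition. Compound 1 gives 16 nM and stands highest of the two numbers, with compound 2 as its nearest neighbour; the step of a 1.0-fold lower number from compound 1 to compound 2 (0.00 log units; within the scatter) lies within the scatter, so the two cannot be told apart.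

Compound 3 `CCCn1c(=O)c2nc(-c3ccc(OCC(=O)NCCNS(=O)(=O)c4ccc(C)cc4)cc3)[nH]c2n(CCC)c1=O` has not yet been measured in this assay. It differs from compound 1 as follows: a group of 11 heavy atoms (7 carbon, 1 nitrogen, 2 oxygen, 1 sulfur; one six-membered aromatic ring of carbon only) in place of a group of 11 heavy atoms (8 carbon, 2 nitrogen, 1 sulfur; one six-membered aromatic ring of carbon only), on a saturated chain carbon, two bonds along the chain from an amide-type nitrogen. The departing group has no common name; the entering group is ((4-methylphenyl)sulfonyl)amino, sitting on a saturated chain carbon, two bonds along the chain from an amide-type nitrogen.

Among the measured compounds shown here, the only measured step, from compound 1 to compound 2, exchanges nitro for methyl on the distant aromatic ring and leaves the chain-end group untouched, so it does not speak to the change made here. For the measured compounds named here, no measured step bears on it. With nothing to point either way, compound 3 is expected to stay near compound 1, giving an estimated 30 nM with a range of 5 nM to 200 nM. The expected step is a 1.9-fold higher number from compound 1 to compound 3 (0.27 log units; within the scatter), kept wide for want of guidance.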

Compound 3, inhibition constant: 72 nM
The estimate for compound 3 lay 2.4-fold (0.38 log units) below the measured number, and the stated range covers the measured number.
By their numbers in this assay, from the lowest: compounds 2 and 1 (each within the scatter of the next); then compound 3.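

Unlike the earlier step, which touched only the distant aromatic ring, this change replaces the chain-end group itself, and in this assay the swap to ((4-methylphenyl)sulfonyl)amino gives a 4.5-fold higher number from compound 1 to compound 3 (0.65 log units; beyond the scatter) as a modest step beyond the usual scatter. This position, on a saturated chain carbon, two bonds along the chain from an amide-type nitrogen, therefore responds to what is placed there, although compound 3 still gives a measurable affinity of 72 nM in the same test. The two groups have the same heavy-atom count and each holds one six-membered aromatic ring of carbon only, but they differ in their other atoms and in their hydrogen-bond donors and acceptors, and nothing available shows which of these differences lies behind the step.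

On these data alone, whether nitro in place of methyl on the aromatic ring of compound 3 would match the result seen with compound 1 and compound 2 remains open. It is also unknown how a urea, a plain amine or a longer chain at this position would compare with these two chain-end groups.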